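Swapping the aryl group on a weak glucosidase-binding lactone

This account rests on a few compounds, and the source may have more. Where it says the series, first, only, none or still open, it means among the compounds named here.

Compound 1, `C=C1CC[C@@H]2[C@](C)(COC(=O)c3cccnc3)[C@H](OC(=O)c3cccnc3)CC[C@@]2(C)[C@@H]1/C=C/C1=C/C(=C\c2ccccc2)OC1=O`: 16000 nM
Compound 2, `C=C1CC[C@@H]2[C@](C)(COC(=O)c3cccnc3)[C@H](OC(=O)c3cccnc3)CC[C@@]2(C)[C@@H]1/C=C/C1=C/C(=C\c2cccc(Br)c2)OC1=O`: 14000 nM

Both were tested in an assay on isolated protein for inhibition of Maltase-glucoamylase (Homo sapiens); on this read-out lower numbers stand for stronger inhibition and higher numbers for weaker inhibition. For the measured compounds named here, compound 2 has the lowest of the two numbers, but its nearest neighbour compound 1 lies within the scatter, so the two cannot be told apart; the only measured step, a 1.1-fold lower number from compound 1 to compound 2 (0.06 log units; within the scatter), shows this. Compound 3, `C=C1CC[C@@H]2[C@](C)(COC(=O)c3cccnc3)[C@H](OC(=O)c3cccnc3)CC[C@@]2(C)[C@@H]1/C=C/C1=C/C(=C\c2ccc(N(C)C)cc2)OC1=O`, carries 4-(dimethylamino)phenyl in place of 3-bromophenyl on a double-bonded chain carbon bound to a double-bonded ring carbon. Going by the values given here, no measured step covers this change; the one step that altered the same aryl group stayed within the scatter. The step is therefore expected to be a 1.1-fold higher number from compound 2 to compound 3 (0.03 log units; within the scatter). Compound 3 is estimated at 15000 nM, between 6000 nM and 40000 nM.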

Compound 3, half-maximal inhibitory concentration: 25000 nM
The estimate for compound 3 lay 1.7-fold (0.22 log units) below the measured number; the measured number falls inside the stated range.
By their numbers in this assay, from the lowest: compounds 2, 1 and 3 (each within the scatter of the next).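

With dimethylamino, a nitrogen-bearing substituent joins bromo on the aromatic ring, and in this assay the result still stays within the scatter: the swap of 3-bromophenyl for 4-(dimethylamino)phenyl gives (a 1.8-fold higher number from compound 2 to compound 3 (0.25 log units; within the scatter)), and dimethylamino in place of hydrogen gives (a 1.6-fold higher number from compound 1 to compound 3 (0.19 log units; within the scatter)). Across these three compounds, no aryl change at this position has yet produced a step beyond the scatter. No supporting measurement offers an explanation for this. Still open, going by these compounds, is whether a carboxylic acid on the aromatic ring, or a pyridine ring in place of it, would produce a clear step.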